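Replacing the acetamido group of compound 3 with phenyl

The compounds below may be only part of what the source reports. "The series", "measured", "known", "first", "only" and "open" are said of these compounds alone.

The study covers three measured compounds and one that has not yet been tested. Compound 1 is `CC(=O)Nc1cccc(-c2ccc(C(=O)N(Cc3cccc(OCCCCCC(=O)O)c3)C(C)C)cc2)c1`, compound 2 is `CCOC(=O)CCCCCOc1cccc(CN(C(=O)c2ccc(-c3cccc4ccccc34)cc2)C(C)C)c1`, and compound 3 is `CCOC(=O)CCCCCOc1cccc(CN(C(=O)c2ccc(-c3cccc(NC(C)=O)c3)cc2)C(C)C)c1`. In an ADME assay on HepG2 cells (Homo sapiens) for cytotoxicity, read by CellTiter-Glo and resazurin assay, with a stated time of 72 h (a higher number here means that more compound is needed for the effect, a lower number that less compound is needed), compound 1 reaches only the limit of the assay, > 26000 nM. In this assay compound 2 likewise gives only the limit, > 26000 nM. Compound 3 also stops at the limit in this assay, > 26000 nM. Compound 3 therefore stands only on a limit, and the two compounds around it stand on the same limit, (the limit of > 26000 nM in this assay, at which 3 of the 3 values shown sit). The step that the two limits leave unreadable from compound 1 to compound 3 cannot be read, and the step that the two limits leave unreadable from compound 2 to compound 3 cannot be read either.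

Compound 4 is `CCOC(=O)CCCCCOc1cccc(CN(C(=O)c2ccc(-c3cccc(-c4ccccc4)c3)cc2)C(C)C)c1`. It differs from compound 3 in one place: phenyl in place of acetamido on an aromatic carbon. Neither measured step bears readably on this change, since both are hidden by the limit, so no size or direction of step can be taken from them. Compound 4 is expected to behave like compound 3 and to sit at the same limit, with the step from compound 3 to compound 4 estimated as a step that the limit leaves unreadable from compound 3 to compound 4. The estimate for compound 4 is 30000 nM, between 12000 nM and 80000 nM.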

Compound 4, half-maximal effective concentration: > 26000 nM
Compound 4: only a limit was reported; the forecaster's own chance of this, stated with the estimate: 75%; the middle value is on the limit's open side.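

In this assay compound 4 gives only a limit, > 26000 nM. No new step can be read from compound 4 to compound 3 or compound 2, as all the compounds shown stop at the same limit: the limit of > 26000 nM in this assay, at which 4 of the 4 values shown sit.

The compounds shown leave open whether any of these changes, including phenyl in place of acetamido, alters the concentration needed in this assay.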